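The source may hold more compounds than are shown below. What is called first, only, known or untested is meant among the compounds shown, and "the series" means these compounds.

Measured compounds:
compound 1, `O=S(=O)(c1ccc(F)cc1)c1cnc2cc(F)ccc2c1-c1ccc(F)cc1`, giving 1.34 mL/min in an ADME assay on microsomes from liver (Homo sapiens) for metabolic stability, tested at 2.5 uM; on this read-out lower numbers stand for slow clearance and higher numbers for fast clearance
compound 2, `O=S(=O)(c1ccc(F)cc1)c1cnc2cc(F)ccc2c1-c1ccc(Cl)cc1`, giving 1.23 mL/min in this assay
compound 3, `Cc1ccc(S(=O)(=O)c2cnc3c(F)cccc3c2-c2cccc(F)c2)cc1F`, giving 3.92 mL/min in this assay

Compound 1 and compound 2 share one core and differ only by chloro in place of fluoro on an aromatic carbon. The step of a 1.1-fold lower number from compound 1 to compound 2 (0.04 log units; within the scatter) is within the scatter, so the two values cannot be ordered. Compound 3 rests on a different core; how the two cores differ is not broken down here. Compound 3 stands highest of the three numbers in this assay, and its distances to compound 1 and compound 2 are both beyond the scatter.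

Compound 4, `Cc1ccc(S(=O)(=O)c2cnc3c(F)cccc3c2-c2cccc(Cl)c2)cc1F`, has not been measured in this assay. It differs from compound 3 by chloro in place of fluoro on an aromatic carbon. This is the same kind of change as that from compound 1 to compound 2, but not the same: there the chloro enters para to a large group, here meta to a large group, and the surrounding core is different.

Among the compounds with values here, only one measured instance of this kind of change exists, and it gave a step within the scatter. On that basis compound 4 is expected to stay close to compound 3, with an expected step of a 1.1-fold lower number from compound 3 to compound 4 (0.03 log units; within the scatter) in this assay, because the change from compound 1 to compound 2 gave a 1.1-fold lower number from compound 1 to compound 2 (0.04 log units; within the scatter). The estimate for compound 4 in this assay is 3.7 mL/min, with a range from 2 mL/min to 6.8 mL/min, the width reflecting that the change is carried over from one core to another.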

Compound 4, intrinsic clearance in a liver preparation (reported as CLH), per the amount of preparation that the assay uses: 3.18 mL/min
Beside the measured number, compound 4's estimate is 1.2-fold (0.07 log units) above it; the measured number falls inside the stated range.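

In this assay the change from 3-fluorophenyl to 3-chlorophenyl on the core of compound 3 gives a 1.2-fold lower number from compound 3 to compound 4 (0.09 log units; within the scatter) and leaves the two compounds unordered. On both cores shown the change stays within the scatter, and the two steps cannot be told apart, so for these two pairs it carries over from one core to the other as a step too small to read: the same change on two cores in this assay, a 1.1-fold lower number (0.04 log units; within the scatter) from compound 1 to compound 2 and a 1.2-fold lower number (0.09 log units; within the scatter) from compound 3 to compound 4, 1.1-fold (0.05 log units) apart, within the scatter of two such steps
Within the data shown here, this rests on only two pairs, and it does not show that the same holds on further cores, at other places on the ring or in any other read-out; nor does it say why the steps are so small.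

The compounds shown hold only fluoro or chloro at this place, so it stays open whether a group of another kind there, such as an amine, a methoxy or a carboxylic acid, would give a step beyond the scatter in this assay. As far as these compounds go, the cores of compound 1 and compound 3 differ in more than one place, and it also stays open which of those differences goes with the higher clearance number of compound 3.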